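The source may report more compounds than this note shows. Statements on the series, on what has been measured and on what is new or still open speak of the compounds shown alone.

Values in an ADME assay on HPLF cells (Homo sapiens) for cytotoxicity, with a stated time of 24 h (a higher number here means that more compound is tolerated, a lower number that less compound is tolerated), for the series, each one a limit of the assay and not a number:

compound 1 (`O=C1/C(=C/c2ccc(Cl)cc2)CCC/C1=C\c1ccccc1[N+](=O)[O-]`) gives (> 400000 nM)
compound 2 (`CN(C)c1ccc(/C=C2\CCC/C(=C\c3ccccc3[N+](=O)[O-])C2=O)cc1`) gives (> 400000 nM)
compound 3 (`Cc1ccc(/C=C2\CCC/C(=C\c3ccccc3[N+](=O)[O-])C2=O)cc1`) gives (> 400000 nM)

Compound 3 stands at (> 400000 nM), which is a limit. It shares that position with the other two measured compounds, as the summary shows (the limit of > 400000 nM in this assay, at which 3 of the 3 values shown sit). No numerical value is therefore available as a starting point.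

Compound 4 (`COc1ccc(/C=C2\CCC/C(=C\c3ccccc3[N+](=O)[O-])C2=O)cc1`) differs from compound 3 in one place (methoxy in place of methyl on an aromatic carbon), with methoxy in place of methyl on an aromatic carbon, that is, 4-methylphenyl to 4-methoxyphenyl.

Three measured steps change a group at that same carbon: (a step that the two limits leave unreadable from compound 1 to compound 3), (a step that the two limits leave unreadable from compound 2 to compound 3) and (a step that the two limits leave unreadable from compound 1 to compound 2). None has a readable size, so they give no measured direction or magnitude for the new exchange. They show only that chloro, dimethylamino and methyl all leave the read-out at the limit.

On that basis, no step beyond the scatter is expected, and the estimated step is (a number no higher from compound 3 to compound 4 (the limit leaves the size open)). A report as a limit is the most likely outcome in this assay for compound 4. As a numerical estimate, compound 4 is expected at (400000 nM), with an estimated range from (200000 nM) to (800000 nM).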

Compound 4, half-maximal cytotoxic concentration: 386000 nM
Estimate against measurement, compound 4: 1.0-fold (0.02 log units) above; the range from low to high includes it.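

In this assay, for the compounds shown here, compound 4 gives 386000 nM, the first reading at this aromatic carbon that is a number and not a limit of the assay. Set against the three limits, the 4-methoxyphenyl compound shows an at least 1.0-fold lower number from compound 3 to compound 4 (0.01 log units; that floor lies within the scatter), an at least 1.0-fold lower number from compound 2 to compound 4 (0.01 log units; that floor lies within the scatter) and an at least 1.0-fold lower number from compound 1 to compound 4 (0.01 log units; that floor lies within the scatter), so methoxy in place of methyl, dimethylamino or chloro gives no step shown to lie beyond the scatter. The steps among compound 1, compound 2 and compound 3 cannot be read, and limits still make up most of the series: the limit of > 400000 nM in this assay, at which 3 of the 4 values shown sit.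

As far as these compounds go, the true size of any gap between compound 4 and compound 1, compound 2 or compound 3 stays open, as does whether a carboxylic acid, a primary amine or a longer alkoxy chain at this carbon would move the read-out beyond the scatter. From the compounds shown here alone, whether changes elsewhere on the shared core would move it also stays open.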